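Aryl series at the shared core: furan to thiophene step

The source may hold more compounds than are shown below. What is called first, only, known or untested is meant among the compounds shown, and "the series" means these compounds.

Measured so far in a functional assay on CEM-DNR-bulk cells (Homo sapiens), read by MTT assay, with a stated time of 72 h; on this read-out lower numbers stand for stronger inhibition and higher numbers for weaker inhibition:
compound 1, `Nc1nc(N)c2c(-c3cc4ccccc4o3)cn([C@@H]3O[C@H](CO)[C@@H](O)[C@H]3O)c2n1`: > 20000 nM
compound 2, `Nc1nc(N)c2c(-c3ccccc3)cn([C@@H]3O[C@H](CO)[C@@H](O)[C@H]3O)c2n1`: > 20000 nM
compound 3, `Nc1nc(N)c2c(-c3ccco3)cn([C@@H]3O[C@H](CO)[C@@H](O)[C@H]3O)c2n1`: > 20000 nM

Compound 3 stands only at a limit of this assay, not at a number. The same holds for compound 1 and for compound 2, so all three values sit at the limit of > 20000 nM in this assay, at which 3 of the 3 values shown sit. For the measured compounds named here, the steps a step that the two limits leave unreadable from compound 1 to compound 2, a step that the two limits leave unreadable from compound 1 to compound 3 and a step that the two limits leave unreadable from compound 2 to compound 3 therefore cannot be read in size or direction; nothing so far separates the three aromatic groups on the shared core.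

Compound 4, `Nc1nc(N)c2c(-c3cccs3)cn([C@@H]3O[C@H](CO)[C@@H](O)[C@H]3O)c2n1`, differs from compound 3 by thiophen-2-yl in place of furan-2-yl on an aromatic carbon. Going by the values given here, no measured step bears readably on this change; the closest, a step that the two limits leave unreadable from compound 2 to compound 3, is itself unreadable. With every value at the limit, no step beyond the scatter can be expected in either direction, and the most likely outcome for compound 4 in this assay is again a limit rather than a number. Compound 4 is estimated at 30000 nM, with a range of 10000 nM to 100000 nM. The expected step that the limit leaves unreadable from compound 3 to compound 4 is accordingly none beyond the scatter.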

Compound 4, half-maximal inhibitory concentration: > 20000 nM
Compound 4 gave a limit, no number (the forecaster's own chance of this, stated with the estimate: 80%); the middle value does not contradict the limit.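

In this assay compound 4 gives > 20000 nM, a limit and not a number. No step among compound 1, compound 2, compound 3 and compound 4 can be read, since the values share one limit: the limit of > 20000 nM in this assay, at which 4 of the 4 values shown sit.

Still open, going by these compounds, is whether any aromatic group on the shared core gives a number at all in this assay, and how these four groups would then compare.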